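A Triazole Aryl Swap in a Spiro Series

A few compounds are considered here, and "the series" means these few. Any claim that something is new, unique, unknown or untested is made for them only; others in the source may bear on it.

Compound 2, `N#CC1=C(N)Oc2c(N)cc3nc4ccccc4nc3c2C12C(=O)N(Cc1cnnn1-c1ccccc1Br)c1ccccc12`, is the anchor of this account. Within the data shown here, in a functional assay on HepG2 cells (Homo sapiens) for antiproliferative activity, read by MTT assay, with a stated time of 48 h (a lower number here means a stronger inhibitor, a higher number a weaker inhibitor), compound 2 gives 38000 nM, the only full number among the values shown. Compound 1, `N#CC1=C(N)Oc2c(c3nc4ccccc4nc3c3ccccc23)C12C(=O)N(Cc1cnnn1-c1ccccc1Cl)c1ccccc12`, returns > 50000 nM, which is a limit of the assay rather than a number, as the limit of > 50000 nM in this assay, at which 1 of the 2 values shown sits, records. Compound 3, `Cc1ccc(Cl)cc1-n1nncc1CN1C(=O)C2(C(C#N)=C(N)Oc3c(N)cc4nc5ccccc5nc4c32)c2ccccc21`, has not yet been measured; it differs from compound 2 by 5-chloro-2-methylphenyl in place of 2-bromophenyl on an aromatic nitrogen. Among the measured compounds shown here, no measured step of this kind exists here, so the change is expected to shift the readout little, if at all, beyond the usual scatter, the expected step being a 1.1-fold lower number from compound 2 to compound 3 (0.04 log units; within the scatter). Compound 3 is therefore estimated at 35000 nM, within 15000 nM to 80000 nM.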

Compound 3, half-maximal inhibitory concentration: 17300 nM
For compound 3 the middle estimate is 2.0-fold (0.31 log units) above the measured one; the range from low to high includes it.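

Among these compounds, this is the only readable step at this position: in this assay, 5-chloro-2-methylphenyl in place of 2-bromophenyl on the aromatic nitrogen gives a 2.2-fold lower number from compound 2 to compound 3 (0.34 log units; beyond the scatter). The read-out therefore responds to the aryl group here, though modestly. This single swap alters several features of the aryl group together, so it cannot show which one carries the step.

From the compounds shown here alone, whether an unsubstituted phenyl, or an amine or carboxylic acid on this ring, would move the number further stays open. Compound 1 remains a limit of the assay, and no step to it can be read: the limit of > 50000 nM in this assay, at which 1 of the 3 values shown sits.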